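The source may hold more compounds than are shown below. What is called first, only, known or untested is meant among the compounds shown, and "the series" means these compounds.

Three compounds carry the shared core of compound 1 `Cc1cc(Nc2ccn(Cc3cccc4ccccc34)n2)n2nc(SCc3ccc(Br)cc3)nc2n1` and have been tested in a functional assay on MCF7 cells (Homo sapiens) for inhibition, read by MTT assay, with a stated time of 72 h; a higher number here means a weaker inhibitor, a lower number a stronger inhibitor. Compound 1 gives 4310 nM in this assay. Compound 3 `CCCCCc1c(C)nc2nc(SCc3ccc(Cl)cc3)nn2c1Nc1cc(-c2ccccc2)[nH]n1`, which carries a pentyl chain and a 4-chlorobenzyl group on the core, gives 6390 nM in this assay; its number and that of compound 1 lie within the scatter of each other, so nothing separates the two. Compound 1 thus stands at the lower of the two numbers recorded, with compound 3 close by. Compound 2 `Cc1cc(Nc2cc(-c3ccccc3)[nH]n2)n2ncnc2n1` in this assay reaches only a limit, > 50000 nM, and no number is recorded for it (the limit of > 50000 nM in this assay, at which 1 of the 3 values shown sits).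

Compound 4 `Cc1cc(Nc2ccn(Cc3ccc(C(F)(F)F)cc3)n2)n2nc(SCc3ccc(Br)cc3)nc2n1` has not yet been measured. It differs from compound 1 in one place (4-(trifluoromethyl)phenyl in place of naphthalen-1-yl on a saturated chain carbon bound to an aromatic nitrogen). Among the measured compounds shown here, no step between two measured compounds in this set shows how such an exchange at this place moves the number, so the expectation rests on the value of compound 1 alone. The step from compound 1 to compound 4 is expected to be small, within the scatter or at most slightly toward a weaker inhibitor, estimated as a 1.4-fold higher number from compound 1 to compound 4 (0.14 log units; within the scatter). Compound 4 is therefore estimated to give about 6000 nM in this assay, with a likely range from 2000 nM to 20000 nM.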

Compound 4, half-maximal inhibitory concentration: 2280 nM
For compound 4 the middle estimate is 2.6-fold (0.42 log units) above the measured one; the measured number falls inside the stated range.
By their numbers in this assay, from the lowest: compounds 4, 1 and 3 (each within the scatter of the next, the first and the last beyond it). At a limit, above all of these: compound 2.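

In this assay, among the compounds shown here, the exchange of naphthalen-1-yl for 4-(trifluoromethyl)phenyl on a saturated chain carbon bound to an aromatic nitrogen gives a 1.9-fold lower number from compound 1 to compound 4 (0.28 log units; within the scatter), and this is the first step that can be read at this place. One of the two six-membered aromatic rings of carbon only is lost and three fluorine atoms enter at the same count of heavy atoms, yet the two numbers cannot be told apart, so at this place the two groups serve equally well in this assay. Nothing shown accounts for the size of this step.

This is a single pair, and it leaves open whether an unsubstituted benzyl, or a group of another kind at this place such as an amine or a carboxylic acid, would keep the number in the same range. It also leaves open whether the same exchange would give a similar step with a different group elsewhere on the shared core, such as the pentyl chain carried by compound 3.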